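This account rests on a few compounds, and the source may have more. Where it says the series, first, only, none or still open, it means among the compounds named here.

Compound 1, with the structure `CCCCc1c(Cl)cc(N/C=N/OCC)cc1Cl`, is the most lipophilic of the three measured compounds here. In a physicochemical assay for lipophilicity, measured as octanol-water partition (on this read-out higher numbers stand for higher lipophilicity and lower numbers for lower lipophilicity), compound 1 gives 5.6, whereas compound 2, `CCO/N=C/Nc1cc(Cl)c(OC)c(Cl)c1`, gives 3.7 and compound 3, `C=CCOc1c(Cl)cc(N/C=N/OCC)cc1Cl`, gives 4.3. Both steps away from compound 1 are large: a number 1.90 log units lower from compound 1 to compound 2 (beyond the scatter) and a number 1.30 log units lower from compound 1 to compound 3 (beyond the scatter). Between the two ethers the step is smaller, a number 0.60 log units higher from compound 2 to compound 3 (beyond the scatter).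

The unmeasured compound 4 has the structure `CCO/N=C/Nc1cc(Cl)c(OCC(C)C)c(Cl)c1`. It differs from compound 1 in one place: isobutoxy in place of butyl on an aromatic carbon. The steps from compound 1 to compound 2 and to compound 3 both show that swapping the butyl group for an oxygen-linked group lowers this read-out by well over a unit, and the step from compound 2 to compound 3 shows that a longer chain on that oxygen claws part of it back. Isobutoxy carries more carbon than either methoxy or allyloxy, so a drop smaller than either of those two drops is expected, roughly a number 0.50 log units lower from compound 1 to compound 4 (beyond the scatter). Compound 4 is therefore estimated at 5.1, most likely between 4.6 and 5.6.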

Compound 4, partition coefficient: 5
Beside the measured number, compound 4's estimate is 0.10 log units above it, within the range that was stated.
By their numbers in this assay, from the lowest: compound 2; then compound 3; then compound 4; then compound 1.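

At this position, an oxygen-linked group does not have to lower the number by a large amount in this assay: with isobutoxy in place of butyl, the result is a number 0.60 log units lower from compound 1 to compound 4 (beyond the scatter), whereas the methoxy and allyloxy swaps both gave large steps. What sits on the oxygen's carbon also counts for more than the earlier pair showed: isopropyl in place of hydrogen gives a number 1.30 log units higher from compound 2 to compound 4 (beyond the scatter), and isopropyl in place of vinyl gives a number 0.70 log units higher from compound 3 to compound 4 (beyond the scatter). Nothing available here explains why these steps have the sizes they do.

From the compounds shown here alone, it remains open whether a straight butoxy chain would read like the branched isobutoxy group. Also open, going by these compounds, is how the number would respond to an amine or a carboxylic acid at the end of that chain.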